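Swapping an amine on the piperidine ring: what to expect

The source may report more compounds than this note shows. Statements on the series, on what has been measured and on what is new or still open speak of the compounds shown alone.

Two measured compounds share a common core and differ only in the amine attached to the saturated ring on the side chain. In an ADME assay on the whole organism (lung, Rattus norvegicus) for metabolic stability, read by LC-MS (on this read-out higher numbers stand for a longer-lived compound and lower numbers for a shorter-lived compound), compound 1 `Cc1csc2cc([C@H](C)Nc3ncnc(N)c3C#N)c(-c3cccc(CN4CCC(N(C)CC(C)C)CC4)c3)c(=O)n12` gives 9.9 h. In this assay compound 2 `Cc1csc2cc([C@H](C)Nc3ncnc(N)c3C#N)c(-c3cccc(CN(C)CCCCN(C)Cc4ccccc4)c3)c(=O)n12` gives 17.6 h, a number that sits within the usual scatter of the value for compound 1, so the two cannot be told apart.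

Compound 3 `Cc1csc2cc([C@H](C)Nc3ncnc(N)c3C#N)c(-c3cccc(CN4CCC(CN(C)Cc5ccccn5)CC4)c3)c(=O)n12` has not yet been measured. It differs from compound 1 in one place: (methyl((pyridin-2-yl)methyl)amino)methyl in place of isobutyl(methyl)amino on a saturated ring carbon. Among the measured compounds shown here, no pair of measured compounds shows the effect of such an exchange in this assay, so there is nothing to set a direction from. The expected step from compound 1 to compound 3 is a 1.2-fold higher number from compound 1 to compound 3 (0.08 log units; within the scatter), which is no more than the scatter. On that basis compound 3 is estimated at 12 h, with a range from 5 h to 28 h.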

Compound 3, half-life: 10.9 h
For compound 3 the middle estimate is 1.1-fold (0.04 log units) above the measured one; measured number inside the range.
By their numbers in this assay, from the lowest: compounds 1, 3 and 2 (each within the scatter of the next).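

Placing (methyl((pyridin-2-yl)methyl)amino)methyl instead of isobutyl(methyl)amino on this saturated ring carbon gives, in this assay, a 1.1-fold higher number from compound 1 to compound 3 (0.04 log units; within the scatter), the first step measured at this position. The entering group has 10 heavy atoms against 6 and brings a six-membered aromatic ring with 1 hetero atom, yet this larger exchange leaves compound 3 indistinguishable from compound 1 on this read-out. No measurement shown bears on the reason for this result.

This single step changes several things at once, so it cannot separate the contribution of the pyridine ring from that of the rest of the entering group. As far as these compounds go, whether a quite different group on this ring carbon, such as a carboxylic acid or a morpholine, would give a step beyond the scatter remains open.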